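The source may report more compounds than this note shows. Statements on the series, on what has been measured and on what is new or still open speak of the compounds shown alone.

In an in vitro ADME assay on microsomes from liver (Homo sapiens) for metabolic stability, tested at 5 uM (on this read-out higher numbers stand for a longer-lived compound and lower numbers for a shorter-lived compound), compound 2 `CC(C)Cn1nc(-c2cccs2)c(O)c(C2=NS(=O)(=O)c3cc(NS(C)(=O)=O)ccc3N2)c1=O` gives > 1 h, which is a limit and not a number. Compound 1 `COC(C)(C)CCn1nc(-c2cccs2)c(O)c(C2=NS(=O)(=O)c3cc(NS(C)(=O)=O)ccc3N2)c1=O` gives > 1 h, also a limit. Both compounds sit at the same point: the limit of > 1 h in this assay, at which 2 of the 2 values shown sit. Among the compounds with values here, the one measured step is a step that the two limits leave unreadable from compound 1 to compound 2, so no size can be carried over from it. Compound 3 `CC(C)(C)Cn1nc(-c2cccs2)c(O)c(C2=NS(=O)(=O)c3cc(NS(C)(=O)=O)ccc3N2)c1=O` differs from compound 2 by methyl in place of hydrogen on a saturated chain carbon bound to three saturated chain carbons, that is, isobutyl to neopentyl. With no readable step to draw on, no change beyond the scatter is expected in this assay, and no direction can be set. The expected step is a step that the limit leaves unreadable from compound 2 to compound 3. Compound 3 is estimated at 1.5 h, with a range of 0.8 h to 3 h.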

Compound 3, half-life: > 1 h
Compound 3: only a limit was reported (the forecaster's own chance of this, stated with the estimate: 80%); the middle value does not contradict the limit.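

Compound 3 gives > 1 h as a limit and not a number. No new step can be read among compound 1, compound 2 and compound 3, which all sit at the same point: the limit of > 1 h in this assay, at which 3 of the 3 values shown sit.
From the compounds shown here alone, the actual half-lives of these three compounds in this assay remain open, as does any effect of the chain change on them.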